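Fluorophenyl Replaces Methyl on a Piperazine-Bearing Camphor Derivative

The source may report more compounds than this note shows. Statements on the series, on what has been measured and on what is new or still open speak of the compounds shown alone.

Compound 1 `CC1(C)[C@@H]2CC[C@@]1([C@@H](O)CN1CCCCC1)C(=O)C2`: 143000 nM
Compound 2 `CN1CCN(C[C@@H](O)[C@]23CC[C@H](CC2=O)C3(C)C)CC1`: "not determined" (no result reported)
Compound 3 `CN1CCN(C[C@H](O)[C@]23CC[C@H](CC2=O)C3(C)C)CC1`: "not determined" (no result reported)

Among the compounds with values here, in an ADME assay on HEK-293T cells (Homo sapiens) for cytotoxicity, read by MTT assay, with a stated time of 72 h (a higher number here means a weaker inhibitor, a lower number a stronger inhibitor), compound 1 gives 143000 nM, the only number in this set. For compound 2 the entry reads "not determined" (no result reported). For compound 3 the entry likewise reads "not determined" (no result reported), so compound 3 stands without a number of its own; the one thing recorded about the pair is the fact that compounds 2 and 3 differ only in the configuration as drawn.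

Compound 4 `CC1(C)[C@@H]2CC[C@@]1([C@@H](O)CN1CCN(c3ccc(F)cc3)CC1)C(=O)C2` follows from compound 3 by the change (4-fluorophenyl in place of methyl on an amine nitrogen in a ring). Within the data shown here, no step between measured compounds is available to anchor this change, and compound 3 itself has no number, so the expectation rests on the single weak result of compound 1 and on the size of the group that enters. The cytotoxicity of compound 4 in this assay is expected to be somewhat stronger than that of compound 1, a step of moderate size beyond the usual scatter. Compound 4 is therefore estimated at 50000 nM, within a range from 15000 nM to 150000 nM.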

Compound 4, half-maximal inhibitory concentration: 82200 nM
Beside the measured number, compound 4's estimate is 1.6-fold (0.22 log units) below it; measured number inside the range.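

In this assay compound 4 gives 82200 nM, yet no new step can be read: compound 3, which differs from it in one place, carries no value. The compounds shown leave open what 4-fluorophenyl in place of methyl does here, and what configuration does, where the record holds only this: the fact that compounds 2 and 3 differ only in the configuration as drawn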